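Isopropyl in place of methyl on an aromatic nitrogen

The source may report more compounds than this note shows. Statements on the series, on what has been measured and on what is new or still open speak of the compounds shown alone.

In a functional assay on KB cells (Homo sapiens) for inhibition, with a stated time of 72 h (a higher number here means a weaker inhibitor, a lower number a stronger inhibitor), compound 3 (`COc1cc(C(=O)c2ccc3c(ccn3C)c2)cc(OC)c1OC`) gives 13.6 nM and stands within the scatter of compound 2 (`COc1cc(C(=O)c2cccc3c2ccn3C)cc(OC)c1OC`) at 22.1 nM while compound 1 (`COc1cc(C(=O)c2cccc3cc[nH]c23)cc(OC)c1OC`) at 310 nM is clearly a weaker inhibitor. Placing isopropyl in place of methyl on an aromatic nitrogen turns compound 3 into compound 4 (`COc1cc(C(=O)c2ccc3c(ccn3C(C)C)c2)cc(OC)c1OC`). Within the data shown here, no measured pair isolates a change at that nitrogen, so this expectation is loose and starts from compound 3 at 13.6 nM as its anchor. The estimated step is a 2.9-fold higher number from compound 3 to compound 4 (0.47 log units; beyond the scatter) and points to a somewhat weaker inhibitor, although a result within the scatter would not surprise. For compound 4 the estimated value is 40 nM with an expected range of 12 nM to 140 nM in this assay once measured.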

Compound 4, half-maximal inhibitory concentration: 1800 nM
Compound 4: middle estimate off by 45-fold (1.65 log units), on the low side; measured number outside the range, above it.
By their numbers in this assay, from the lowest: compounds 3 and 2 (each within the scatter of the next); then compound 1; then compound 4.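

In this assay, isopropyl in place of methyl on the aromatic nitrogen gives a 130-fold higher number from compound 3 to compound 4 (2.12 log units; beyond the scatter), a large loss from a small change. Among these compounds, this nitrogen is therefore a sensitive position, which the earlier compounds could not show, since none of them formed a pair differing only there. Nothing shown gives a reason for this rise. Still open, on these data alone, is how ethyl or cyclopropyl on this nitrogen would read, and so whether the number climbs gradually or abruptly beyond methyl.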